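Aryl substituent variation on the shared core, cytotoxicity notes

A few compounds are considered here, and "the series" means these few. Any claim that something is new, unique, unknown or untested is made for them only; others in the source may bear on it.

Measured so far in a functional assay on HeLa cells (Homo sapiens) for cytotoxicity, read by MTT assay, with a stated time of 48 h; a lower number here means a stronger inhibitor, a higher number a weaker inhibitor:
compound 1 `Cc1nc2c3ccccc3ccc2c2nc3c(ccc4ccccc43)c(-c3cccc4ccccc34)c12` gives 14900 nM
compound 2 `Cc1nc2c3ccccc3ccc2c2nc3c(ccc4ccccc43)c(-c3ccccc3N)c12` gives 16200 nM
compound 3 `Cc1nc2c3ccccc3ccc2c2nc3c(ccc4ccccc43)c(-c3ccc(O)cc3)c12` gives 4630 nM

Compound 3, bearing the 4-hydroxyphenyl group, stands with the lowest number of the three in this assay. Both a 3.2-fold lower number from compound 1 to compound 3 (0.51 log units; beyond the scatter) and a 3.5-fold lower number from compound 2 to compound 3 (0.54 log units; beyond the scatter) are modest gains for the hydroxyphenyl compound, whereas a 1.1-fold higher number from compound 1 to compound 2 (0.04 log units; within the scatter) shows no difference between the naphthalenyl and the 2-aminophenyl compounds.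

Compound 4 `Cc1ccc(-c2c3ccc4ccccc4c3nc3c2c(C)nc2c4ccccc4ccc32)cc1` is next. Its change from compound 3 reads: methyl in place of hydroxy on an aromatic carbon. Among the measured compounds shown here, no measured step exchanges a hydroxy for a methyl, so the bearing is indirect: the one compound with a hydroxy on that aryl ring, compound 3, has the lowest number, and the two without it, compound 1 and compound 2, sit higher by modest steps. For the measured compounds named here, removing the hydroxy is therefore expected to move the number back upward, toward the region of compound 1 and compound 2, but the methyl has no precedent here and the step could also fall within the scatter.

The estimate for compound 4 in this assay is 10000 nM, with a range of 4000 nM to 25000 nM. This corresponds to an expected step of a 2.2-fold higher number from compound 3 to compound 4 (0.33 log units; beyond the scatter).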

Compound 4, half-maximal inhibitory concentration: 72200 nM
Estimate against measurement, compound 4: 7.2-fold (0.86 log units) below; measured number above the stated range.
By their numbers in this assay, from the lowest: compound 3; then compounds 1 and 2 (each within the scatter of the next); then compound 4.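

In this assay, among the compounds shown here, the exchange of hydroxy for methyl on this aromatic carbon is the largest single step so far, with a 16-fold higher number from compound 3 to compound 4 (1.19 log units; beyond the scatter), so a one-atom change at this position can move the number much further than the earlier compounds showed. The 4-methylphenyl group does not simply return the number to the level of the other two aryl groups, as a 4.5-fold higher number from compound 2 to compound 4 (0.65 log units; beyond the scatter) and a 4.8-fold higher number from compound 1 to compound 4 (0.69 log units; beyond the scatter) both place compound 4 clearly higher, so aryl groups without a hydroxy are not interchangeable here. No measurement at hand accounts for the size of these steps.

The compounds shown leave open whether the large step reflects the loss of the hydroxy, the arrival of the methyl, or both, and a plain phenyl group would help to separate these readings. They also leave open how a methoxy, an amine or a carboxylic acid at the same ring carbon would compare with the 4-hydroxyphenyl compound, and whether any of these groups would give a lower number than compound 3 does.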